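From dimethylphenyl to vinylphenyl on a shared core

This account rests on a few compounds, and the source may have more. Where it says the series, first, only, none or still open, it means among the compounds named here.

- compound 1 `COc1cc(-c2ccnc3cc(-c4ccc(F)cc4)nn23)cc(OC)c1OC` gives 4540 nM
- compound 2 `COc1cc(-c2ccnc3cc(-c4cn(CO)c5ccccc45)nn23)cc(OC)c1OC` gives 93 nM
- compound 3 `COc1cc(-c2ccnc3cc(-c4ccc(C)c(C)c4)nn23)cc(OC)c1OC` gives 391 nM

In a functional assay on B16-F0 cells (Mus musculus) for inhibition, read by CCK-8 assay, with a stated time of 48 h (on this read-out higher numbers stand for weaker inhibition and lower numbers for stronger inhibition), compound 3 (391 nM) stands second highest of the three numbers, with compound 2 (93 nM) lower and compound 1 (4540 nM) higher. Compound 4 `C=Cc1ccc(-c2cc3nccc(-c4cc(OC)c(OC)c(OC)c4)n3n2)cc1` keeps the shared core and changes one group: 4-vinylphenyl in place of 3,4-dimethylphenyl on an aromatic carbon in short, 4-vinylphenyl in place of 3,4-dimethylphenyl on an aromatic carbon.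

Among the compounds with values here, one measured step bears on this carbon. The large step of a 12-fold lower number from compound 1 to compound 3 (1.06 log units; beyond the scatter) shows that exchanging one substituted phenyl for another here can move the number a long way. Within the data shown here, no measured compound carries a vinyl group, so the data offer no direct guide to it. Still, the two groups match in heavy atoms and in their carbon ring, and they differ by the double bond outside the ring. In this assay no step beyond the scatter is therefore expected, and the estimated step is a 1.3-fold higher number from compound 3 to compound 4 (0.11 log units; within the scatter) (a slightly higher number). The large step from the first comparison keeps the expected range wide. Compound 4 is estimated at 500 nM (expected range 130 nM to 2000 nM).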

Compound 4, half-maximal inhibitory concentration: 788 nM
Beside the measured number, compound 4's estimate is 1.6-fold (0.20 log units) below it, and the stated range covers the measured number.
By their numbers in this assay, from the lowest: compound 2; then compounds 3 and 4 (each within the scatter of the next); then compound 1.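

With a 2.0-fold higher number from compound 3 to compound 4 (0.30 log units; within the scatter) in this assay, 4-vinylphenyl and 3,4-dimethylphenyl on this aromatic carbon cannot be told apart, so the double bond outside the ring, and the different arrangement of carbons on the phenyl ring, make no clear difference to the number here. The fluoro group now has a second comparison, a 5.8-fold lower number from compound 1 to compound 4 (0.76 log units; beyond the scatter), so both carbon-bearing phenyl groups give clearly lower numbers than the 4-fluorophenyl group of compound 1, although the vinyl step is the more modest of the two. Nothing among the available findings explains why these groups behave this way.

Going by these compounds, it remains open whether the double bond matters at all, which a plain ethyl group on the phenyl ring would test directly against the vinyl group. Also open is how this carbon would respond to a phenyl ring carrying an amine or a carboxylic acid, since every phenyl group shown here bears only fluoro or small carbon substituents.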